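Chloro in place of trifluoromethoxy: notes on compound 4

The compounds below may be only part of what the source reports. "The series", "measured", "known", "first", "only" and "open" are said of these compounds alone.

Measured in a functional assay on HL-60 cells (Homo sapiens) for cytotoxicity, read by luminescence and CellTiter-Glo, with a stated time of 3 days; a lower number here means a stronger inhibitor, a higher number a weaker inhibitor:
compound 1 `N#Cc1ccc(NC(=O)c2ccc(Br)cc2O)c(Cl)c1` gives 730 nM
compound 2 `O=C(Nc1ccc(OC(F)(F)F)cc1)c1cc(F)ccc1O` gives 850 nM
compound 3 `O=C(Nc1ccc(OC(F)(F)F)c(Cl)c1)c1cc(F)ccc1O` gives 550 nM

Compound 3 lies within the scatter of both compound 1 and compound 2, so no order among the three can be read. Compound 4 `O=C(Nc1ccc(Cl)c(Cl)c1)c1cc(F)ccc1O` carries chloro in place of trifluoromethoxy on an aromatic carbon, ortho to a chloro group chloro in place of trifluoromethoxy on an aromatic carbon in the structure. For the measured compounds named here, the one measured step that bears on this change, a 1.5-fold lower number from compound 2 to compound 3 (0.19 log units; within the scatter), is chloro in place of hydrogen. Going by the values given here, no measured step removes trifluoromethoxy, so the direction remains open. No step beyond the scatter is expected in this assay here. The estimated change, a 1.2-fold higher number from compound 3 to compound 4 (0.07 log units; within the scatter), stays within the scatter. Compound 4 is estimated at 650 nM, with an expected range of 250 nM to 1700 nM.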

Compound 4, half-maximal inhibitory concentration: 660 nM
For compound 4 the middle estimate is 1.0-fold (0.01 log units) below the measured one, and the stated range covers the measured number.
By their numbers in this assay, from the lowest: compounds 3, 4, 1 and 2 (each within the scatter of the next).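

Trifluoromethoxy on an aromatic carbon, ortho to a chloro group, gives way to chloro with no readable change in this assay (a 1.2-fold higher number from compound 3 to compound 4 (0.08 log units; within the scatter)), and this is the first measured step that removes it. This position therefore takes either group, 5 heavy atoms or 1, with the number staying within the scatter. No evidence on the reason for this result is at hand.

As far as these compounds go, whether an amine, a carboxylic acid or a longer chain here would move the number beyond the scatter stays open.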